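The source may hold more compounds than are shown below. What is called first, only, known or untested is meant among the compounds shown, and "the series" means these compounds.

In an ADME assay on microsomes from liver (Rattus norvegicus, strain Sprague-Dawley) for metabolic stability, read by LC-MS, using NADPH, with stated times of 5 min and 60 min, tested at 1 uM (a higher number here means that the compound lasts longer, a lower number that the compound disappears faster), compound 1, with structure `CCCCOC(=O)NS(=O)(=O)c1ccc(CCC)cc1-c1ccc(Cn2c(C(F)(F)F)nc3ccccc32)cc1`, gives 0.117 h. On the numbers at hand this is the lowest of the three measured half-lives. Compound 2, `CCCc1ccc(S(=O)(=O)NC(=O)OCCCC(F)(F)F)c(-c2cc(F)c(Cn3c(C(C)(C)C)nc4ccccc43)c(F)c2)c1`, gives 0.267 h in this assay, a number beyond the scatter above that of compound 1. Compound 3, `CCCc1ccc(S(=O)(=O)NC(=O)OCCCC(F)(F)F)c(-c2ccc(Cn3c(C(C)(C)C)nc4ccccc43)cc2)c1`, gives 0.35 h in this assay, the highest of the three and again beyond the scatter above compound 1. Compounds 2 and 3 differ from compound 1 in more than one place, so no single change accounts for their gap to it.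

The step under consideration leads from compound 1 to compound 4, `CCCCOC(=O)NS(=O)(=O)c1ccc(CCC)cc1-c1ccc(Cn2c(-c3nccs3)nc3ccccc32)cc1`. The difference between the two structures is 1,3-thiazol-2-yl in place of trifluoromethyl on an aromatic carbon. The shared core and the propyl-bearing ring are untouched; only the group between the two ring nitrogen atoms of the fused system changes.

Among the compounds with values here, no pair among the measured compounds shows what this single change does to the half-life, so nothing measured guides the expectation. Compound 1 already stands at the bottom, and the entering group brings a new aromatic ring where a trifluoromethyl stood. The estimated step from compound 1 to compound 4 in this assay is a 1.2-fold lower number from compound 1 to compound 4 (0.07 log units; within the scatter), expected to lie within the scatter or slightly downward. Compound 4 is therefore expected to give about 0.1 h in this assay, with a plausible range from 0.04 h to 0.25 h.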

Compound 4, half-life: 0.267 h
Compound 4: middle estimate off by 2.7-fold (0.43 log units), on the low side, and the stated range ends below it.
By their numbers in this assay, from the lowest: compound 1; then compounds 2, 4 and 3 (each within the scatter of the next).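

In this assay, putting 1,3-thiazol-2-yl in place of trifluoromethyl on the aromatic carbon between two ring nitrogen atoms gives a 2.3-fold higher number from compound 1 to compound 4 (0.36 log units; beyond the scatter). Within the data shown here, this is the first single-place step, and it shows that the half-life responds to the group at this position, with the larger entering group, which brings a five-membered aromatic ring with 2 hetero atoms, raising the number rather than lowering it. Nothing at hand says why the number moves, whether through the departure of trifluoromethyl or the arrival of the new ring.

The compounds shown leave open whether the gain belongs to 1,3-thiazol-2-yl itself or would also come with another group at this position, such as a phenyl ring, a pyridin-2-yl ring, a methyl or a cyclopropyl. Among these compounds, they also leave open whether the same replacement would give a step of similar size on a compound with the other side chain of compound 2 and compound 3, since this single pair is the only view of the change.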